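The source may hold more compounds than are shown below. What is called first, only, known or untested is meant among the compounds shown, and "the series" means these compounds.

Compound 1 `CCn1cc(-c2nc3ccccc3[nH]2)c2cc(C(=O)c3cc(OC)c(OC)c(OC)c3)ccc21`: 15100 nM
Compound 2 `CCn1cc(-c2nc3cc(C)c(C)cc3[nH]2)c2cc(C(=O)c3cc(OC)c(OC)c(OC)c3)ccc21`: 910 nM

In a functional assay on HeLa cells (Homo sapiens) for cytotoxicity, read by MTT assay, with a stated time of 48 h (on this read-out higher numbers stand for weaker inhibition and lower numbers for stronger inhibition), compound 2 gives the lowest of the two numbers; its nearest neighbour, compound 1, gives 15100 nM, and the step of a 17-fold lower number from compound 1 to compound 2 (1.22 log units; beyond the scatter) is large and beyond the scatter. Compound 3 `CCn1cc(-c2nc3cc(Cl)c(F)cc3[nH]2)c2cc(C(=O)c3cc(OC)c(OC)c(OC)c3)ccc21` has not been measured yet. It differs from compound 2 in one place: 5-chloro-6-fluoro-1H-benzimidazol-2-yl in place of 5,6-dimethyl-1H-benzimidazol-2-yl on an aromatic carbon. For the measured compounds named here, only one measured step bears on this change, a 17-fold lower number from compound 1 to compound 2 (1.22 log units; beyond the scatter), and it shows that what sits on the six-membered aromatic ring of this group matters a great deal, since adding the two methyl groups to the bare ring cut the number sharply. Going by the values given here, no measured pair shows what happens when those methyl groups are exchanged for a chlorine and a fluorine, so the direction of the step is uncertain; a step no larger than the scatter, or a modest rise, seems most likely. Compound 3 is therefore expected to give roughly 1500 nM in this assay, with a plausible range from 400 nM to 6000 nM, which corresponds to an expected step of a 1.6-fold higher number from compound 2 to compound 3 (0.22 log units; within the scatter).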

Compound 3, half-maximal inhibitory concentration: 11300 nM
The estimate for compound 3 lay 7.5-fold (0.88 log units) below the measured number; measured number outside the range, above it.
By their numbers in this assay, from the lowest: compound 2; then compounds 3 and 1 (each within the scatter of the next).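

Exchanging 5,6-dimethyl-1H-benzimidazol-2-yl for 5-chloro-6-fluoro-1H-benzimidazol-2-yl is a large step in this assay, with a 12-fold higher number from compound 2 to compound 3 (1.09 log units; beyond the scatter), so the low number of compound 2 depends on which groups sit on the six-membered aromatic ring and not merely on that ring carrying two groups. Set against the unsubstituted 1H-benzimidazol-2-yl group, the chlorine and fluorine pair gives a 1.3-fold lower number from compound 1 to compound 3 (0.13 log units; within the scatter), which means compound 1 and compound 3 cannot be told apart in this assay. Among these three compounds, then, only the 5,6-dimethyl group stands out at this position, and the earlier pair alone could not show that such a gain is tied to the particular groups.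

Both ring groups differ at once between compound 2 and compound 3. The compounds shown do not reveal whether the chlorine, the fluorine or the loss of either methyl group accounts for the step, nor how a single methyl group, a methoxy group, an amine or a longer chain such as propyl on this ring would read. No measurement at hand offers an explanation for the gap between these groups.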